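This account rests on a few compounds, and the source may have more. Where it says the series, first, only, none or still open, it means among the compounds named here.

Measured compounds:
Compound 1 `Cc1ccc2nc(Cn3c(=O)n(C4CC4)c4ccncc43)c(CCCCO)n2c1` — in an ADME assay on HEp-2 cells (Homo sapiens) for cytotoxicity, read by CCK-8 assay, with a stated time of 6 days (a lower number here means that less compound is tolerated, a higher number that more compound is tolerated), compound 1 reaches only the assay limit, > 100000 nM.
Compound 2 `CCc1ccn2c(CCCCO)c(Cn3c(=O)n(C4CC4)c4ccncc43)nc2c1` — in this assay compound 2 likewise reaches only the assay limit, > 100000 nM.
Compound 3 `O=c1n(Cc2cn3ccc(Cl)cc3n2)c2cnccc2n1C1CC1` — in this assay compound 3 gives 22300 nM.

Among the three, compound 3 is the only one that gives an actual number in this assay; the other two sit at the limit of > 100000 nM in this assay, at which 2 of the 3 values shown sit, so no measured step can be drawn between any pair of them. Among the compounds with values here, compound 3 therefore stands alone as the one compound whose tolerated concentration is known.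

Compound 4 `CS(=O)(=O)CCNC(=O)c1c(Cn2c(=O)n(C3CC3)c3ccncc32)nc2cc(Cl)ccn12` is the new compound. It keeps the whole skeleton of compound 3 and differs in one spot: (2-(methylsulfonyl)ethyl)carbamoyl in place of hydrogen on an aromatic carbon. In plain words, a hydrogen on the shared core is swapped for a chain that carries an amide and a sulfone.

Within the data shown here, because no step between measured compounds exists here, the size of the effect cannot be read from the data. Compounds 1 and 2, which also carry larger groups on the core than compound 3 does, both sit at the limit of > 100000 nM in this assay, at which 2 of the 3 values shown sit, and that is the only hint available. On that basis compound 4 is expected to be tolerated somewhat better than compound 3, a change described by a 2.2-fold higher number from compound 3 to compound 4 (0.35 log units; beyond the scatter). The estimate for compound 4 in this assay is 50000 nM, with a likely range from 15000 nM to 150000 nM.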

Compound 4, half-maximal cytotoxic concentration: > 100000 nM
Compound 4 gave a limit, no number; the forecaster's own chance of this, stated with the estimate: 35%; middle value at least 2.0-fold (0.30 log units) from the limit.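

Within the data shown here, this is the first step that can be tied to a single change: (2-(methylsulfonyl)ethyl)carbamoyl in place of hydrogen on an aromatic carbon gives, in this assay, an at least 4.4-fold higher number from compound 3 to compound 4 (0.65 log units; beyond the scatter). The earlier compounds shown here offered no such step, whereas this one shows that the spot next to the ring nitrogen, on the five-membered aromatic ring, can carry a chain with an amide and a sulfone while the tolerated concentration rises beyond the usual scatter. The true size of the rise stays unknown, as compound 4 gives only an assay limit, and that limit is shared by most of the compounds shown: the limit of > 100000 nM in this assay, at which 3 of the 4 values shown sit.

The compounds shown cannot say whether the amide, the sulfone or simply the presence of a chain accounts for this step, and a plain carboxylic acid or a small methyl amide at the same position would help to separate these. They also leave open how much cytotoxicity remains in compound 4 at concentrations past the limit.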